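The source may hold more compounds than are shown below. What is called first, only, known or untested is meant among the compounds shown, and "the series" means these compounds.

In a physicochemical assay for solubility, measured as kinetic solubility, with a stated time of 1 h, at pH 7.4 (on this read-out lower numbers stand for lower solubility and higher numbers for higher solubility), compound 2 `CC(=O)Nc1nc(-c2ccc(Cl)cc2)cs1` gives 1000 nM and compound 3 `CC(=O)Nc1nc(-c2cccc(Cl)c2)cs1` gives 2000 nM, two values that lie within the usual scatter of each other. Compound 1 `CC(=O)Nc1nc(-c2ccc(Cl)c(Cl)c2)cs1` reads < 1000 nM, which is a limit of the assay and not a number.

Compound 4 `CC(=O)Nc1nc(-c2ccc(Cl)c(F)c2)cs1` differs from compound 2 by fluoro in place of hydrogen on an aromatic carbon, ortho to a chloro group: fluoro in place of hydrogen on an aromatic carbon.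

Among the compounds with values here, two measured steps bear on this change, and both put hydrogen in place of chloro on an aromatic carbon. One is a number no lower from compound 1 to compound 2 (the limit leaves the size open), and the other is an at least 2.0-fold higher number from compound 1 to compound 3 (0.30 log units; that floor lies within the scatter). Both start from the limit of < 1000 nM in this assay, at which 1 of the 3 values shown sits, so neither has a firm size. Both also run the opposite way, with a halogen leaving rather than entering, and chloro is not fluoro. Read in reverse, they give only a weak hint towards a lower number, so no change beyond the scatter is expected.

The expected change is a 1.1-fold lower number from compound 2 to compound 4 (0.05 log units; within the scatter). Compound 4 is estimated at 900 nM, with an expected range of 400 nM to 2000 nM.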

Compound 4, solubility: 5000 nM
Compound 4: middle estimate off by 5.6-fold (0.74 log units), on the low side; the measured number lies above the stated range.
By their numbers in this assay, from the lowest: compounds 2 and 3 (each within the scatter of the next); then compound 4.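

Fluoro in place of hydrogen on an aromatic carbon, ortho to a chloro group, gives a 5.0-fold higher number from compound 2 to compound 4 (0.70 log units; beyond the scatter) in this assay and so shows that this position can respond to a fluoro group, whereas the earlier steps only removed a chloro group. Fluoro in place of chloro at the same position gives an at least 5.0-fold higher number from compound 1 to compound 4 (0.69 log units; beyond the scatter) and so shows that the two halogens do not read alike here. The size of that second step is only a floor, since compound 1 carries a limit and not a number: the limit of < 1000 nM in this assay, at which 1 of the 4 values shown sits.

From the compounds shown here alone, whether fluoro gives a similar rise at other places on the ring, or without the chloro group, remains open. Also open, going by these compounds, is how a methoxy group or an amine would read at this position.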